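Reattaching the ring substituent directly to the aryl carbon

The source may hold more compounds than are shown below. What is called first, only, known or untested is meant among the compounds shown, and "the series" means these compounds.

Among the compounds with values here, compound 3 `FC(F)(F)c1c(-c2ccc(CNC3CCOCC3)c(Cl)c2)ccn2c(CC3CC3)nnc12` gives 631 nM in a functional assay on cells for positive allosteric modulation of metabotropic glutamate receptor 2 (Homo sapiens), read by scintillation counting and GTPgammaS binding, with a stated time of 30 min (on this read-out lower numbers stand for an effect already at smaller amounts and higher numbers for an effect only at larger amounts of compound), the highest number of the three measured members; compound 1 `Fc1cc(-c2ccn3c(CC4CC4)nnc3c2Cl)ccc1NC1CC1` gives 63.1 nM and compound 2 `FC(F)(F)c1c(-c2ccc(NC3CCOCC3)c(Cl)c2)ccn2c(CC3CC3)nnc12` gives 18.6 nM. Compound 4 `O[C@H]1CC[C@H](Oc2ccc(-c3ccn4c(CC5CC5)nnc4c3C(F)(F)F)cc2Cl)CC1` differs from compound 3 by (4-hydroxycyclohexyl)oxy in place of ((oxan-4-yl)amino)methyl on an aromatic carbon. Within the data shown here, the one measured step that bears on this change is a 34-fold higher number from compound 2 to compound 3 (1.53 log units; beyond the scatter), where the (oxan-4-yl)amino of compound 2 became the ((oxan-4-yl)amino)methyl of compound 3. Among the measured compounds shown here, compound 4 reverts to a substituent seated on the aromatic carbon itself, as in compound 2, though with an oxygen link and a carbocyclic ring bearing a hydroxy group; no measured pair covers that exchange, so the size of the reversal is uncertain. A large step back downward is nevertheless expected, with the estimated change being a 21-fold lower number from compound 3 to compound 4 (1.32 log units; beyond the scatter), because the step of a 34-fold higher number from compound 2 to compound 3 (1.53 log units; beyond the scatter) was itself large. Compound 4 is therefore expected to give about 30 nM in this assay, with a range from 8 nM to 120 nM.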

Compound 4, half-maximal effective concentration: 25.1 nM
For compound 4 the middle estimate is 1.2-fold (0.08 log units) above the measured one; the measured number falls inside the stated range.
By their numbers in this assay, from the lowest: compounds 2 and 4 (each within the scatter of the next); then compound 1; then compound 3.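

In this assay, the aromatic carbon ortho to a chloro group accepts (4-hydroxycyclohexyl)oxy in place of ((oxan-4-yl)amino)methyl with a 25-fold lower number from compound 3 to compound 4 (1.40 log units; beyond the scatter), so the high number of compound 3 does not extend to this other substituent of the same heavy-atom count. Against the directly attached amine, (4-hydroxycyclohexyl)oxy gives a 1.3-fold higher number from compound 2 to compound 4 (0.13 log units; within the scatter), so an oxygen link with a carbocyclic hydroxy-bearing ring and a nitrogen link with an oxan-4-yl ring cannot be told apart here. No measurement at hand gives a reason for either step.

Link and ring change together between these compounds, so (oxan-4-yl)oxy and (4-hydroxycyclohexyl)amino would be needed to read each change alone. On these data alone, whether ((4-hydroxycyclohexyl)oxy)methyl would repeat the large rise seen with ((oxan-4-yl)amino)methyl also stays open.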